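Cytotoxicity notes: ester chain to carboxycarbonyl replacement

This account rests on a few compounds, and the source may have more. Where it says the series, first, only, none or still open, it means among the compounds named here.

Compound 1 `COC(=O)CNC1=CS(=O)(=O)O[C@@]12[C@@H](CO[Si](C)(C)C(C)(C)C)O[C@@H](n1cc(C)c(=O)n(C)c1=O)[C@@H]2O[Si](C)(C)C(C)(C)C` gives 160000 nM in a functional assay on HEL cells (Homo sapiens); on this read-out lower numbers stand for higher toxicity in this test and higher numbers for lower toxicity in this test. Compound 2 `COC(=O)CCNC1=CS(=O)(=O)O[C@@]12[C@@H](CO[Si](C)(C)C(C)(C)C)O[C@@H](n1cc(C)c(=O)n(C)c1=O)[C@@H]2O[Si](C)(C)C(C)(C)C` gives 94000 nM and stands lowest of the two numbers, though a 1.7-fold lower number from compound 1 to compound 2 (0.23 log units; within the scatter) is within the scatter, so neither ranks as more toxic. Compound 3 `Cc1cn([C@@H]2O[C@H](CO[Si](C)(C)C(C)(C)C)[C@@]3(OS(=O)(=O)C=C3NCC(=O)C(=O)O)[C@H]2O[Si](C)(C)C(C)(C)C)c(=O)n(C)c1=O` carries carboxycarbonyl in place of (methoxycarbonyl)methyl on a saturated chain carbon bound to an amine nitrogen. Within the data shown here, no measured step bears on this change; the only step, from an ester chain to a longer ester chain, stayed within the scatter. No step beyond the scatter is therefore expected, and compound 3 is estimated at 120000 nM (range 50000 nM to 300000 nM), meaning an expected step of a 1.3-fold higher number from compound 2 to compound 3 (0.11 log units; within the scatter).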

Compound 3, half-maximal cytotoxic concentration: 146000 nM
Beside the measured number, compound 3's estimate is 1.2-fold (0.09 log units) below it, and the stated range covers the measured number.
By their numbers in this assay, from the lowest: compounds 2, 3 and 1 (each within the scatter of the next).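

Working notes: in this assay, carboxycarbonyl in place of (methoxycarbonyl)methyl on a saturated chain carbon bound to an amine nitrogen stays within the scatter (a 1.6-fold higher number from compound 2 to compound 3 (0.19 log units; within the scatter)). Carboxy in place of methoxy on a carbonyl carbon does too (a 1.1-fold lower number from compound 1 to compound 3 (0.04 log units; within the scatter)), so this position now holds a group carrying a hydrogen-bond donor with no step beyond the scatter. Nothing available explains these results.

From the compounds shown here alone, whether an amine or a simple amide at this position would give a step beyond the scatter stays open.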